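A few compounds are considered here, and "the series" means these few. Any claim that something is new, unique, unknown or untested is made for them only; others in the source may bear on it.

Measured so far in a functional assay on A-431 cells (Homo sapiens) for antiproliferative activity, read by sulforhodamine B assay, with a stated time of 72 h; a higher number here means a weaker inhibitor, a lower number a stronger inhibitor:
- compound 1 `CS(=O)(=O)CCNC(=O)Nc1cc2c(Nc3ccc(F)c(Cl)c3)ncnc2cc1O[C@H]1CCOC1`: 1570 nM
- compound 2 `COCCCNC(=O)Nc1cc2c(Nc3ccc(F)c(Cl)c3)ncnc2cc1O[C@H]1CCOC1`: 4100 nM

Compound 2 gives the higher of the two numbers in this assay; its nearest neighbour is compound 1, and the step of a 2.6-fold higher number from compound 1 to compound 2 (0.42 log units; beyond the scatter) separates them. Compound 3 `COC(CCNC(=O)Nc1cc2c(Nc3ccc(F)c(Cl)c3)ncnc2cc1O[C@H]1CCOC1)OC` is not yet measured. It differs from compound 2 by methoxy in place of hydrogen on a saturated chain carbon bound to an oxygen on a saturated carbon and a saturated chain carbon, that is, methoxymethyl becomes dimethoxymethyl at the end of the chain. Among the measured compounds shown here, the only measured step, a 2.6-fold higher number from compound 1 to compound 2 (0.42 log units; beyond the scatter), exchanged the whole terminal group and bears on this change only loosely; no measured pair shows the effect of a second methoxy on the same chain carbon. Nothing here points to a direction, so the step is expected to stay within the scatter, a 1.1-fold higher number from compound 2 to compound 3 (0.04 log units; within the scatter). Compound 3 is therefore estimated at 4500 nM in this assay, with a range from 1800 nM to 11000 nM.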

Compound 3, half-maximal inhibitory concentration: 22000 nM
Beside the measured number, compound 3's estimate is 4.9-fold (0.69 log units) below it, and the stated range ends below it.
By their numbers in this assay, from the lowest: compound 1; then compound 2; then compound 3.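

In this assay, the end of the chain proves sensitive to a small addition: moving from 3-methoxypropyl to 3,3-dimethoxypropyl gives a 5.4-fold higher number from compound 2 to compound 3 (0.73 log units; beyond the scatter), so a second methoxy on the same saturated chain carbon is not a neutral change. The exchange of the whole terminal group now spans a wider range than the earlier comparison showed, with a 14-fold higher number from compound 1 to compound 3 (1.15 log units; beyond the scatter), and compound 1 keeps the lowest number of the three. Nothing available on these compounds accounts for the size of this loss.

On these data alone, whether a terminal hydroxyl, an amine or a carboxylic acid on the same chain would lower the number remains open. Also open, as far as these compounds go, is how a longer chain ending in a single methoxy would compare with compound 2.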